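Swapping Trifluoromethyl for Fluoro on a Shared Core

The compounds below may be only part of what the source reports. "The series", "measured", "known", "first", "only" and "open" are said of these compounds alone.

Two compounds built on the same core have been examined in an ADME assay on the whole organism for pharmacokinetics, with Rattus norvegicus as the target, at a dose of 3 mg/kg by the intravenous route; on this read-out higher numbers stand for wider distribution into tissues and lower numbers for narrower distribution. Compound 1 `COC(=O)N[C@H](C(=O)N1CCC[C@H]1C(=O)Nc1ccc([C@H]2CC[C@H](c3ccc(NC(=O)[C@@H]4CCCN4C(=O)[C@@H](NC(=O)OC)C(C)C)cc3)N2c2ccc(C(F)(F)F)cc2)cc1)C(C)C` gives 1.3 L/kg in this assay. Compound 2 `COC(=O)N[C@H](C(=O)N1CCC[C@H]1C(=O)Nc1ccc([C@H]2CC[C@H](c3ccc(NC(=O)[C@@H]4CCCN4C(=O)[C@@H](NC(=O)OC)[C@@H](C)OC)cc3)N2c2ccc(F)cc2)cc1)[C@@H](C)OC`, which carries fluoro on the aryl group at the central ring and methoxy-bearing side chains at both ends, gives 0.9 L/kg in this assay. Of the two numbers, that of compound 1 and that of compound 2 sit within the usual scatter of one another, so the data do not separate them.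

Compound 3 `COC(=O)N[C@H](C(=O)N1CCC[C@H]1C(=O)Nc1ccc([C@H]2CC[C@H](c3ccc(NC(=O)[C@@H]4CCCN4C(=O)[C@@H](NC(=O)OC)C(C)C)cc3)N2c2ccc(F)cc2)cc1)C(C)C` has not yet been measured in this assay. Compared with compound 1, the change is fluoro in place of trifluoromethyl on an aromatic carbon. Within the data shown here, no step with this exact change has been measured here. Given that compound 2 gives 0.9 L/kg, the step of a 1.2-fold lower number from compound 1 to compound 3 (0.07 log units; within the scatter) is expected to stay small, if anything downward, and not beyond the scatter. Compound 3 is therefore estimated at 1.1 L/kg in this assay, within a range from 0.6 L/kg to 1.9 L/kg.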

Compound 3, volume of distribution at steady state: 0.5 L/kg
The estimate for compound 3 lay 2.2-fold (0.34 log units) above the measured number; the whole stated range lies above it.
By their numbers in this assay, from the lowest: compounds 3, 2 and 1 (each within the scatter of the next, the first and the last beyond it).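

In this assay, putting fluoro in place of trifluoromethyl on an aromatic carbon, para to a large group, gives a 2.6-fold lower number from compound 1 to compound 3 (0.41 log units; beyond the scatter). This is the only step shown that changes this position and nothing else, so it establishes that this one substituent can shift distribution by more than the usual scatter while the rest of the molecule stays the same. Nothing available explains this shift, so the reason for it remains unknown.

A single pair cannot show how the read-out responds across different groups at this position, so chloro, methyl, methoxy or a small amine could each fall anywhere relative to these two compounds. Going by these compounds, it also remains open whether the same swap would have a similar effect on a compound with the methoxy-bearing side chains of compound 2.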